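Benzyl ester in place of methyl ester on compound 1

This account rests on a few compounds, and the source may have more. Where it says the series, first, only, none or still open, it means among the compounds named here.

For the measured compounds named here, compound 1 `CCOC(=O)C1=C(C)NC(C)=C(C(=O)OC)C1c1[nH]c(CC)nc1Cl` is the weakest binder of the three measured members: in an assay on ileum for inhibition of Voltage-dependent L-type calcium channel subunit alpha-1C (Cavia porcellus) (a lower number here means a stronger inhibitor, a higher number a weaker inhibitor), compound 1 gives 2.02 nM. Its nearest neighbour is compound 3 `CCc1nc(Cl)c(C2C(C(=O)OC(C)C)=C(C)NC(C)=C2C(=O)OC(C)C)[nH]1`, which in this assay gives 0.748 nM; compound 2 `CCOC(=O)C1=C(C)NC(C)=C(C(=O)OCC)C1c1[nH]c(CC)nc1Cl` in this assay gives 0.158 nM. Going by the values given here, the single change that has been measured from compound 1 is a 13-fold lower number from compound 1 to compound 2 (1.11 log units; beyond the scatter), a large step toward stronger binding.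

Compound 4 `CCc1nc(Cl)c(C2C(C(=O)OC)=C(C)NC(C)=C2C(=O)OCc2ccccc2)[nH]1` differs from compound 1 by phenyl in place of methyl on a saturated chain carbon bound to an oxygen next to a carbonyl group. Among the compounds with values here, no measured pair covers a phenyl entering at this place, so only the step from compound 1 to compound 2 bears on it, and it shows that enlarging the ester at this place moved the number sharply down. A benzyl ester is a larger change than an ethyl ester, and the direction is expected to be the same, although its size is uncertain. Compound 4 is therefore expected to bind more strongly than compound 1, with the step estimated as a 5.1-fold lower number from compound 1 to compound 4 (0.70 log units; beyond the scatter). In this assay compound 4 is expected to give about 0.4 nM, within a range from 0.1 nM to 1.6 nM.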

Compound 4, half-maximal inhibitory concentration: 1.75 nM
Compound 4: the middle estimate sits 4.4-fold (0.64 log units) below what was measured; the measured number lies above the stated range.
By their numbers in this assay, from the lowest: compound 2; then compound 3; then compounds 4 and 1 (each within the scatter of the next).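

In this assay, ethoxycarbonyl to benzyloxycarbonyl gives a 1.2-fold lower number from compound 1 to compound 4 (0.06 log units; within the scatter) and so shows that phenyl in place of methyl at this place leaves the number unchanged within the scatter. The methyl ester stays in this change, whereas a 13-fold lower number from compound 1 to compound 2 (1.11 log units; beyond the scatter) arises at the other ester, where methyl becomes ethyl, so the large step seen there does not carry over to the ester changed here. Nothing on hand gives a reason for the difference between these two steps.

Still open, from the compounds shown here alone, is whether a longer chain, such as butyl, or a phenethyl ester at this place would also stay within the scatter of compound 1. Also open, going by these compounds, is whether benzyl at the ester that went from methyl to ethyl would give a step as large as that one.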